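Hydrogen in place of chloro: what compound 4 should give

This account rests on a few compounds, and the source may have more. Where it says the series, first, only, none or still open, it means among the compounds named here.

Measured so far:
Compound 1, `Fc1ccc(NC(=S)N/N=C\c2ccnc3ccccc23)cc1`, gives 1100 nM in a functional assay on MCF7 cells (Homo sapiens) for cytotoxicity, read by MTT assay, with a stated time of 48 h; a lower number here means a stronger inhibitor, a higher number a weaker inhibitor.
Compound 2, `S=C(N/N=C\c1ccnc2ccccc12)Nc1cccnc1`, gives 970 nM in this assay.
Compound 3, `S=C(N/N=C\c1ccnc2ccccc12)Nc1ccc(Cl)cc1`, gives 1070 nM in this assay.

Compound 3 holds the second highest of the three numbers; its nearest neighbour is compound 1, and the gap between them, a 1.0-fold lower number from compound 1 to compound 3 (0.01 log units; within the scatter), lies within the scatter, as does the gap to compound 2, a 1.1-fold higher number from compound 2 to compound 3 (0.04 log units; within the scatter). The three compounds share one core and differ only in the group on the amide-type nitrogen.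

Compound 4, `S=C(N/N=C\c1ccnc2ccccc12)Nc1ccccc1`, continues from compound 3 by hydrogen in place of chloro on an aromatic carbon.

Among the measured compounds shown here, two measured steps bear on this change, both on the same nitrogen-bound ring: a 1.0-fold lower number from compound 1 to compound 3 (0.01 log units; within the scatter) and a 1.1-fold higher number from compound 2 to compound 3 (0.04 log units; within the scatter). Neither moved the number beyond the scatter, and the step of a 1.1-fold lower number from compound 1 to compound 2 (0.05 log units; within the scatter) did not either. Nothing in these data shows the group on this ring moving the number in this assay, so compound 4 is expected to sit alongside compound 3, with a step of a 1.0-fold higher number from compound 3 to compound 4 (0.01 log units; within the scatter) that stays within the scatter. Compound 4 is therefore estimated at 1100 nM, with a range from 550 nM to 2200 nM.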

Compound 4, half-maximal inhibitory concentration: 1070 nM
Beside the measured number, compound 4's estimate is 1.0-fold (0.01 log units) above it; the measured number falls inside the stated range.
By their numbers in this assay, from the lowest: compounds 2, 3, 4 and 1 (each within the scatter of the next).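

In this assay, hydrogen in place of chloro on the aromatic carbon para to a large group gives no change at the digits printed from compound 3 to compound 4 (within the scatter), and hydrogen in place of fluoro at that carbon gives a 1.0-fold lower number from compound 1 to compound 4 (0.01 log units; within the scatter), so a halogen at this position is not needed for the number seen here. The earlier compounds shown here all carried a halogen or a ring nitrogen, whereas phenyl itself now matches them, with phenyl in place of pyridin-3-yl giving a 1.1-fold higher number from compound 2 to compound 4 (0.04 log units; within the scatter). No evidence is available that would explain this flat result.

From the compounds shown here alone, whether an amine, a carboxylic acid or a longer chain on this carbon would move the number in this assay remains open. So does whether any change to the shared core would move it.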